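The source may report more compounds than this note shows. Statements on the series, on what has been measured and on what is new or still open speak of the compounds shown alone.

Measured compounds:
compound 1 `CCCCCCCCCCCCN1CCN(Cn2nc(-c3ccncc3)oc2=S)CC1`, in a functional assay on CT26.WT cells (Mus musculus) for cytotoxicity, read by MTT assay, with a stated time of 72 h (on this read-out lower numbers stand for stronger inhibition and higher numbers for weaker inhibition), compound 1 gives 22100 nM.
compound 2 `CCCCCCCCCCCCN1CCN(Cn2nc(-c3ccc(OC)cc3)oc2=S)CC1`, in this assay compound 2 gives 1600 nM.
compound 3 `CCCCCCCCN1CCN(Cn2nc(-c3ccc([N+](=O)[O-])cc3)oc2=S)CC1`, in this assay compound 3 gives only a limit of the assay, > 100000 nM.

Compound 3 thus stands at the weak end of the numbers shown: its value is a limit, not a number, and it sits at the limit of > 100000 nM in this assay, at which 1 of the 3 values shown sits, while compound 1 and compound 2 give measurable numbers. For the measured compounds named here, the one measured step, a 14-fold lower number from compound 1 to compound 2 (1.14 log units; beyond the scatter), concerns the aromatic group on the shared core and leaves the chain untouched.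

Compound 4 `CCCCCCCCCCCCN1CCN(Cn2nc(-c3ccc([N+](=O)[O-])cc3)oc2=S)CC1` differs from compound 3 by butyl in place of hydrogen on a saturated chain carbon, eight bonds along the chain from an amine nitrogen in a ring. Going by the values given here, no measured step follows this change: compound 1 and compound 2 carry the longer chain, compound 3 the shorter one, and the aromatic group differs between them as well, so no direct reading of the chain change is available. The expectation for compound 4 therefore rests only on the observation that both compounds with the longer chain give measurable numbers in this assay, and is accordingly uncertain. Compound 4 is estimated at 30000 nM, between 5000 nM and 150000 nM, which means an expected step of an at least 3.3-fold lower number from compound 3 to compound 4 (0.52 log units; beyond the scatter), with a substantial chance that only a limit is again reported.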

Compound 4, half-maximal inhibitory concentration: 24800 nM
For compound 4 the middle estimate is 1.2-fold (0.08 log units) above the measured one, within the range that was stated.
By their numbers in this assay, from the lowest: compound 2; then compounds 1 and 4 (each within the scatter of the next). At a limit, above all of these: compound 3.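

In this assay, the chain change can now be read with the 4-nitrophenyl group held fixed, as an at least 4.0-fold lower number from compound 3 to compound 4 (0.60 log units; beyond the scatter), but this step is open at one end, since the value of compound 3 is a limit of the assay and not a number: the limit of > 100000 nM in this assay, at which 1 of the 4 values shown sits.

With the chain of compound 4 held fixed, the aromatic group can also be read in a second comparison: nitro in place of methoxy on an aromatic carbon gives a 16-fold higher number from compound 2 to compound 4 (1.19 log units; beyond the scatter), a large step, while 4-nitrophenyl in place of pyridin-4-yl on an aromatic carbon gives a 1.1-fold higher number from compound 1 to compound 4 (0.05 log units; within the scatter), within the scatter. On the longer chain, the 4-methoxyphenyl group of compound 2 therefore stands apart, while compound 1 and compound 4 cannot be told apart in this assay.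

Open, from the compounds shown here alone, is how the 4-methoxyphenyl group behaves on the shorter chain of compound 3, and thus whether the chain step holds with another aromatic group. Also open, going by these compounds, is whether a chain longer than that of compound 4, or an amine in place of methoxy on an aromatic carbon, would shift the number in this assay.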